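The source may report more compounds than this note shows. Statements on the series, on what has been measured and on what is new or still open speak of the compounds shown alone.

Measured so far in a functional assay on thoracic aorta (Rattus norvegicus, strain Wistar), with a stated time of 15 min; on this read-out higher numbers stand for an effect only at larger amounts of compound and lower numbers for an effect already at smaller amounts 
- compound 1 `CCOc1ccc(Cl)cc1C(C)NC(=O)NS(=O)(=O)c1ccc(C)cc1` gives > 300000 nM as a limit
- compound 2 `CCOc1ccc(Cl)cc1C(C)NC(=O)NS(=O)(=O)c1ccccc1` gives > 300000 nM as a limit

For the measured compounds named here, compound 2 is known only as a limit, and the series so far comes down to the limit of > 300000 nM in this assay, at which 2 of the 2 values shown sit, with no number to work from. Moving on to compound 3 `CCOc1ccc(Cl)cc1C(C)NC(=O)NS(=O)(=O)c1ccc(Cl)cc1` puts chloro in place of hydrogen on an aromatic carbon, phenyl to 4-chlorophenyl, counted as chloro in place of hydrogen on an aromatic carbon in this change. Going by the values given here, the one measured step that bears on it is a step that the two limits leave unreadable from compound 1 to compound 2 and it gives no size to carry over. No step beyond the scatter is therefore expected in this assay and no direction can be argued. The estimated step is a number no higher from compound 2 to compound 3 (the limit leaves the size open) as the working expectation. For compound 3 the estimate is 300000 nM with an expected range from 100000 nM to 600000 nM and another limit is the likeliest report.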

Compound 3, half-maximal effective concentration: 281000 nM
Compound 3: middle estimate off by 1.1-fold (0.03 log units), on the high side, and the stated range covers the measured number.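

Compound 3 is the only compound shown with a number rather than a limit in this assay, so the aromatic carbon para to a large group now has one readable value. Chloro in place of hydrogen gives an at least 1.0-fold lower number from compound 2 to compound 3 (0.02 log units; that floor lies within the scatter), and chloro in place of methyl gives an at least 1.0-fold lower number from compound 1 to compound 3 (0.02 log units; that floor lies within the scatter). Both steps are known only as floors within the scatter, so neither change is shown to separate compound 3 from the other two, and the series stays close to the assay limit: the limit of > 300000 nM in this assay, at which 2 of the 3 values shown sit.

On these data alone, the true size of both steps remains open, since each starts from a limit. Also open, as far as these compounds go, is whether an amine, a carboxylic acid or a longer chain at this same position would give a number clearly removed from that limit.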